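Cyano in place of methoxycarbonyl on the shared core

The compounds below may be only part of what the source reports. "The series", "measured", "known", "first", "only" and "open" are said of these compounds alone.

Of the compounds shown here, three with one core and one varied group have been measured in a functional assay for inhibition, with Homo sapiens as the target; a higher number here means a weaker inhibitor, a lower number a stronger inhibitor. Compound 1 `CC(O)c1cc(-c2ccccc2)c2ccc(OCc3cccc(C4(O)CCOCC4)c3)cc2c1`, carrying 1-hydroxyethyl, gives 28 nM. Compound 2 `COCc1cc(-c2ccccc2)c2ccc(OCc3cccc(C4(O)CCOCC4)c3)cc2c1`, carrying methoxymethyl, gives 4 nM. Compound 3 `COC(=O)c1cc(-c2ccccc2)c2ccc(OCc3cccc(C4(O)CCOCC4)c3)cc2c1`, carrying methoxycarbonyl, gives 3 nM. Compound 3 thus stands level with compound 2 within the scatter, and well clear of compound 1.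

Compound 4 `N#Cc1cc(-c2ccccc2)c2ccc(OCc3cccc(C4(O)CCOCC4)c3)cc2c1` has cyano in place of methoxycarbonyl on an aromatic carbon, meta to a phenyl group: cyano in place of methoxycarbonyl on an aromatic carbon. Among the measured compounds shown here, no cyano compound has been measured, so the evidence is indirect. The two steps beyond the scatter, a 7.0-fold lower number from compound 1 to compound 2 (0.85 log units; beyond the scatter) and a 9.3-fold lower number from compound 1 to compound 3 (0.97 log units; beyond the scatter), both start from 1-hydroxyethyl, a group not involved here. For the measured compounds named here, the closest precedent exchanges one of the other two groups for the other, a 1.3-fold lower number from compound 2 to compound 3 (0.12 log units; within the scatter), and stays within the scatter.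

No step beyond the scatter is therefore expected, and the expected step is a 1.7-fold higher number from compound 3 to compound 4 (0.22 log units; within the scatter). In this assay, compound 4 is estimated at 5 nM, with an expected range of 2 nM to 15 nM.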

Compound 4, half-maximal inhibitory concentration: 3 nM
Beside the measured number, compound 4's estimate is 1.7-fold (0.22 log units) above it; low and high end bracket the measured number.
By their numbers in this assay, from the lowest: compounds 3, 4 and 2 (each within the scatter of the next); then compound 1.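

In this assay, cyano puts no oxygen on this aromatic carbon, unlike the three groups before it, yet it stands level with methoxycarbonyl (no change at the digits printed from compound 3 to compound 4 (within the scatter)) and with methoxymethyl (a 1.3-fold lower number from compound 2 to compound 4 (0.12 log units; within the scatter)), so among these compounds an oxygen in this group is not required. Among the compounds shown here, the gap from 1-hydroxyethyl recurs with this third group (a 9.3-fold lower number from compound 1 to compound 4 (0.97 log units; beyond the scatter)), leaving 1-hydroxyethyl as the only one of the four groups set apart beyond the scatter. Nothing available explains why these three groups read alike at this position.

Hydroxymethyl would help show whether the hydroxyl or the branching methyl of 1-hydroxyethyl goes with the weaker number. Going by these compounds, it also remains open whether an amine, a carboxylic acid or a primary amide on this carbon would stay level with compounds 2, 3 and 4.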